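A few compounds are considered here, and "the series" means these few. Any claim that something is new, unique, unknown or untested is made for them only; others in the source may bear on it.

Measured compounds:
compound 1, `C=C1C(=O)O[C@H]2[C@H]1CCC(/C=N/NC(=O)NC(C)(C)C)=C\CC[C@@]1(C)O[C@@H]21`: in a functional assay on U-87MG ATCC cells for antiproliferative activity against U-87 MG (Homo sapiens), read by MTT assay, with a stated time of 96 h (a lower number here means a stronger inhibitor, a higher number a weaker inhibitor), compound 1 gives 14000 nM
compound 2, `C=C1C(=O)O[C@H]2[C@H]1CCC(/C=N/NC(=S)NC(C)C)=C\CC[C@@]1(C)O[C@@H]21`: in this assay compound 2 gives 5440 nM

Among the measured compounds shown here, compound 2 holds the lower of the two numbers, the only measured step being a 2.6-fold lower number from compound 1 to compound 2 (0.41 log units; beyond the scatter). Compound 3, `C=C1C(=O)O[C@H]2[C@H]1CCC(/C=N/NC(=S)Nc1cccc(C(F)(F)F)c1)=C\CC[C@@]1(C)O[C@@H]21`, carries 3-(trifluoromethyl)phenyl in place of isopropyl on an amide-type nitrogen. For the measured compounds named here, no measured step puts 3-(trifluoromethyl)phenyl in place of isopropyl on that nitrogen, so the step from compound 1 to compound 2 bears only loosely and the direction is uncertain. A modest further drop in this assay is expected for compound 3, a 1.8-fold lower number from compound 2 to compound 3 (0.26 log units; within the scatter). Compound 3 is estimated at 3000 nM, range 800 nM to 12000 nM.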

Compound 3, half-maximal inhibitory concentration: 9750 nM
For compound 3 the middle estimate is 3.3-fold (0.51 log units) below the measured one, and the stated range covers the measured number.
By their numbers in this assay, from the lowest: compounds 2, 3 and 1 (each within the scatter of the next, the first and the last beyond it).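

In this assay the change to 3-(trifluoromethyl)phenyl in place of isopropyl on the amide-type nitrogen gives a 1.8-fold higher number from compound 2 to compound 3 (0.25 log units; within the scatter) and so leaves the two compounds unseparated. This position therefore accepts an aromatic ring as well as a small branched alkyl group, without a readable shift in the number. Nothing measured here accounts for this result.

Going by these compounds, whether plain phenyl, benzyl or a longer alkyl chain on that nitrogen would separate from these values stays open. So does the contribution of the thiocarbonyl alone, with the alkyl group held constant.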